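Bromo for nitro on the compound 1 scaffold

The source may hold more compounds than are shown below. What is called first, only, known or untested is meant among the compounds shown, and "the series" means these compounds.

Measured compounds:
compound 1 `O=c1cc(-c2ccccc2)oc2cc(N3COc4c(cccc4[N+](=O)[O-])C3)ccc12` — 1.96%
compound 2 `O=c1cc(-c2ccccc2)oc2ccc(N3COc4c(Br)cc(Br)cc4C3)cc12` — 13.6%
compound 3 `O=c1cc(-c2ccccc2)oc2ccc(N3COc4c(cccc4[N+](=O)[O-])C3)cc12` — 55.9%

In a functional assay on MCF7 cells (Homo sapiens) for inhibition, read by MTT assay, with a stated time of 48 h, tested at 15 ug/mL (a higher number here means more inhibition of growth at the concentration tested, a lower number less inhibition of growth), compound 1 gives 1.96%, the lowest of the three numbers. Compound 2 gives 13.6% and compound 3 gives 55.9%; both numbers lie beyond the scatter above compound 1. Going by the values given here, no two of the measured compounds differ in only one place, so no single-change step is known in this assay.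

Compound 4 `O=c1cc(-c2ccccc2)oc2cc(N3COc4c(Br)cccc4C3)ccc12` differs from compound 1 by bromo in place of nitro on an aromatic carbon. Among the compounds with values here, with no matching step among the measured compounds, the expected step from compound 1 to compound 4 in this assay is a number 8 percentage points higher from compound 1 to compound 4 (within the scatter), a small rise at most, since compound 2, which also carries bromo, shows only 13.6%. Compound 4 is expected to give 10%, in the range 0% to 30%.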

Compound 4, percent growth inhibition at one concentration: 5.64%
Estimate against measurement, compound 4: 4.4 percentage points above, within the range that was stated.
By their numbers in this assay, from the lowest: compounds 1, 4 and 2 (each within the scatter of the next, the first and the last beyond it); then compound 3.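

In this assay, going by these compounds alone, bromo in place of nitro on this aromatic carbon of the core of compound 1 gives a number 3.7 percentage points higher from compound 1 to compound 4 (within the scatter) and this is the first step that changes one place only. At this position, the change from nitro to bromo therefore does not move the read-out beyond the scatter. No measurement at hand bears on this result.

Going by these compounds, whether an amine or a carboxylic acid on the same aromatic carbon would give a step beyond the scatter stays open. So does the size of the same change from nitro to bromo on the core of compound 3.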